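The compounds below may be only part of what the source reports. "The series", "measured", "known", "first", "only" and "open" are said of these compounds alone.

Compound 1 `O=C(N/N=C/c1ccc(F)cc1)Nc1ccc(Oc2ccnc3[nH]ccc23)c(F)c1` stands lowest of the two numbers in a functional assay on A549 cells (Homo sapiens) for antiproliferative activity, read by MTT assay, with a stated time of 72 h; on this read-out higher numbers stand for weaker inhibition and lower numbers for stronger inhibition; compound 1 gives 680 nM. Compound 2 `O=C(N/N=C/c1cccc([N+](=O)[O-])c1)Nc1ccc(Oc2ccnc3[nH]ccc23)c(F)c1` gives 3640 nM, and the step of a 5.4-fold higher number from compound 1 to compound 2 (0.73 log units; beyond the scatter) shows that exchanging the group on the carbon with a double bond to nitrogen can move the number beyond the scatter. Compound 3 `O=C(N/N=C/c1cc(Br)c(O)c(Br)c1)Nc1ccc(Oc2ccnc3[nH]ccc23)c(F)c1` carries the change (3,5-dibromo-4-hydroxyphenyl in place of 4-fluorophenyl on a carbon with a double bond to nitrogen). Going by the values given here, only that one measured step bears on it; it was modest and toward a higher number. For compound 3 a step in the same direction, of uncertain size, is therefore expected, a 2.2-fold higher number from compound 1 to compound 3 (0.34 log units; beyond the scatter). Compound 3 is estimated at 1500 nM, range 500 nM to 5000 nM.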

Compound 3, half-maximal inhibitory concentration: 16200 nM
Estimate against measurement, compound 3: 11-fold (1.03 log units) below; measured number outside the range, above it.
By their numbers in this assay, from the lowest: compound 1; then compound 2; then compound 3.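

Exchange on the carbon with a double bond to nitrogen can cost far more than the nitro case indicated: 3,5-dibromo-4-hydroxyphenyl gives a 24-fold higher number from compound 1 to compound 3 (1.38 log units; beyond the scatter) in this assay and also gives a 4.5-fold higher number from compound 2 to compound 3 (0.65 log units; beyond the scatter) against 3-nitrophenyl. Among these three aryl groups, 4-fluorophenyl therefore keeps the lowest number, and both other groups lie beyond the scatter from it. Nothing at hand explains this order. Open, as far as these compounds go, is whether the rise follows the two bromines, the hydroxyl or their combination. Also open, from the compounds shown here alone, is whether 4-hydroxyphenyl, 3,5-dibromophenyl or 4-dimethylaminophenyl here would stay near compound 1.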